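This account rests on a few compounds, and the source may have more. Where it says the series, first, only, none or still open, it means among the compounds named here.

Compound 1 `CC(C)c1n[nH]c2c(NCc3ccc(-c4ccccn4)cc3)nc(SC(C)C(C)O)nc12`: 190 nM
Compound 2 `CC(C)c1n[nH]c2c(NCc3ccc(-c4ccccn4)cc3)nc(SCCn3ccnc3)nc12`: 155 nM
Compound 3 `CC(C)c1n[nH]c2c(NCc3ccc(-c4ccccn4)cc3)nc(SCC(C)(C)O)nc12`: 507 nM

In a functional assay on HT cells (Homo sapiens) for antiproliferative activity, read by fluorescence, with a stated time of 72 h (a higher number here means a weaker inhibitor of growth, a lower number a stronger inhibitor of growth), compound 3 gives the highest number of the three, with a 2.7-fold higher number from compound 1 to compound 3 (0.43 log units; beyond the scatter) and a 3.3-fold higher number from compound 2 to compound 3 (0.51 log units; beyond the scatter). Compound 4 `CC(C)c1n[nH]c2c(NCc3ccc(-c4ccccn4)cc3)nc(SCCCN)nc12` differs from compound 3 in one place: 2-aminoethyl in place of 1-hydroxy-1-methylethyl on a saturated chain carbon bound to a sulfur. Among the compounds with values here, no measured step replaces this group with 2-aminoethyl, so the two steps leading to compound 3 are the only guide. Within the data shown here, both moved beyond the scatter, each by a modest amount, when a different chain replaced the one on compound 3, and a step of similar size back toward a lower number is expected here, as a 2.3-fold lower number from compound 3 to compound 4 (0.36 log units; beyond the scatter). Compound 4 is therefore estimated at 220 nM, within a range from 90 nM to 550 nM.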

Compound 4, concentration for 50% growth inhibition: 120 nM
For compound 4 the middle estimate is 1.8-fold (0.26 log units) above the measured one, within the range that was stated.
By their numbers in this assay, from the lowest: compounds 4, 2 and 1 (each within the scatter of the next); then compound 3.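

In this assay, the 3-aminopropyl chain on the sulfur gives a 4.2-fold lower number from compound 3 to compound 4 (0.63 log units; beyond the scatter) and so recovers what the 2-hydroxy-2-methylpropyl chain lacks. Against the other chains, the steps of a 1.3-fold lower number from compound 2 to compound 4 (0.11 log units; within the scatter) and a 1.6-fold lower number from compound 1 to compound 4 (0.20 log units; within the scatter) both stay within the scatter, so a chain ending in an amine serves here as well as those two. Compound 3 alone stands apart, yet compound 1 also carries a hydroxyl, so a hydroxyl by itself does not set it apart. Whether a carboxylic acid or a longer chain bearing the amine would match these numbers remains open, and nothing available explains the differences among these chains.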